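From dichlorophenyl to difluorophenyl in a growth assay

A few compounds are considered here, and "the series" means these few. Any claim that something is new, unique, unknown or untested is made for them only; others in the source may bear on it.

Compound 1 `O=S(=O)(/C=C/c1ccc(O)cc1)Cc1ccc(Nc2ncnc3ccc(Br)cc23)cc1` in a functional assay on PC-3 cells (Homo sapiens) (a higher number here means a weaker inhibitor of growth, a lower number a stronger inhibitor of growth), gives 42000 nM
Compound 2 `O=S(=O)(/C=C/c1ccc(Cl)cc1Cl)Cc1ccc(Nc2ncnc3ccc(Br)cc23)cc1` in this assay gives 4000 nM

Compound 2 holds the lower of these two numbers. The next structure, compound 3 `O=S(=O)(/C=C/c1ccc(F)cc1F)Cc1ccc(Nc2ncnc3ccc(Br)cc23)cc1` differs from it in one place 2,4-difluorophenyl in place of 2,4-dichlorophenyl on a double-bonded chain carbon bound to a double-bonded chain carbon on a double-bonded chain carbon. Going by the values given here, the only measured step at this place is large: an 11-fold lower number from compound 1 to compound 2 (1.02 log units; beyond the scatter) but it replaced 4-hydroxyphenyl, a different exchange. Among the compounds with values here, no measured pair compares chlorine with fluorine, so a much smaller step is expected in this assay tentatively towards a higher number. The expected change is a 1.6-fold higher number from compound 2 to compound 3 (0.21 log units; within the scatter) as an estimate. Compound 3 is estimated at 6500 nM with an expected range of 2500 nM to 18000 nM for this measurement.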

Compound 3, concentration for 50% growth inhibition: 100000 nM
Estimate against measurement, compound 3: 15-fold (1.19 log units) below; measured number outside the range, above it.
By their numbers in this assay, from the lowest: compound 2; then compound 1; then compound 3.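

In this assay the identity of the halogen matters strongly at this position: exchanging 2,4-dichlorophenyl for 2,4-difluorophenyl, with the same heavy-atom count, gives a 25-fold higher number from compound 2 to compound 3 (1.40 log units; beyond the scatter) in this pair. The difluorophenyl ring also falls behind 4-hydroxyphenyl, with a 2.4-fold higher number from compound 1 to compound 3 (0.38 log units; beyond the scatter) here, so among these compounds the gain belongs to the dichlorophenyl ring and not to two halogens as such. Nothing available here explains this gap.

On these data alone, whether one chlorine alone carries the gain stays open, as does how a 2,4-dibromophenyl or 2,4-dimethylphenyl ring would fare here.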